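Changing the amine ring at the end of the chain

The source may hold more compounds than are shown below. What is called first, only, known or untested is meant among the compounds shown, and "the series" means these compounds.

Measured so far:
- Compound 1, `COc1cc2c(Oc3ccc(NC(=O)N/N=C/c4ccc([N+](=O)[O-])cc4)cc3F)ccnc2cc1OCCCN1CCCC1`, in a functional assay on MDA-MB-231 cells (Homo sapiens) for cytotoxicity, read by MTT assay, with a stated time of 72 h (a higher number here means a weaker inhibitor, a lower number a stronger inhibitor), gives 970 nM.
- Compound 2, `COc1cc2c(Oc3ccc(NC(=O)N/N=C/c4ccc(C(F)(F)F)cc4)cc3F)ccnc2cc1OCCCN1CCCC1`, in this assay gives 1800 nM.
- Compound 3, `COc1ccc(/C=N/NC(=O)Nc2ccc(Oc3ccnc4cc(OCCCN5CCCCC5)c(OC)cc34)c(F)c2)c(OC)c1`, in this assay gives "not determined" (no result reported), that is, no result reported.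

Compound 1 and compound 2 sit within the scatter of each other: a 1.9-fold higher number from compound 1 to compound 2 (0.27 log units; within the scatter), where a trifluoromethyl takes the place of a nitro on an aromatic carbon. Compound 1 therefore cannot be set apart from compound 2 on the numbers shown, and compound 3 contributes no number at all.

Compound 4, `COc1cc2c(Oc3ccc(NC(=O)N/N=C/c4ccc([N+](=O)[O-])cc4)cc3F)ccnc2cc1OCCCN1CCC(C)CC1`, differs from compound 1 only at the far end of the chain: 4-methylpiperidin-1-yl in place of pyrrolidin-1-yl on a saturated chain carbon, three bonds along the chain from an oxygen on an aromatic ring. Among the compounds with values here, no measured step touches this part of the molecule; the single step from compound 1 to compound 2 concerns a substituent on the distant aromatic ring and says nothing about the amine ring. With no guide from the data, the expectation is that compound 4 stays close to compound 1, with an expected step of a 1.0-fold higher number from compound 1 to compound 4 (0.01 log units; within the scatter) that does not go beyond the scatter. Compound 4 is therefore estimated at 1000 nM in this assay, with a range from 350 nM to 3000 nM.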

Compound 4, half-maximal inhibitory concentration: 870 nM
Compound 4: middle estimate off by 1.1-fold (0.06 log units), on the high side; low and high end bracket the measured number.
By their numbers in this assay, from the lowest: compounds 4, 1 and 2 (each within the scatter of the next, the first and the last beyond it).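

In this assay, the step at the far end of the chain is a 1.1-fold lower number from compound 1 to compound 4 (0.05 log units; within the scatter), with 4-methylpiperidin-1-yl, a six-membered ring of 7 heavy atoms, in place of pyrrolidin-1-yl, a five-membered ring of 5 heavy atoms. Within the data shown here, this is the first measured step at this position, and it shows that for this pair, with the nitro group kept in place, the amine ring can be exchanged without a change that stands out from the scatter. Nothing available bears on why these two compounds cannot be told apart.

Both rings compared here are saturated and hold a single nitrogen, so the compounds shown leave open what a morpholine ring, an open-chain dimethylamine or a carboxylic acid at this position would do, and the same goes for a chain longer than the propyl chain. From the compounds shown here alone, it also remains open whether 4-methylpiperidin-1-yl would behave the same way alongside the trifluoromethyl group of compound 2, and compound 3, with its own amine ring, gives no result to help.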